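Chromone series: replacing the hexyl chain on the shared core

A few compounds are considered here, and "the series" means these few. Any claim that something is new, unique, unknown or untested is made for them only; others in the source may bear on it.

Measured so far:
compound 1, `CCCCCCc1c(F)c(N)c2c(=O)cc(-c3ccc(N)c(F)c3)oc2c1F`: > 10000 nM
compound 2, `Nc1ccc(-c2cc(=O)c3c(N)c(F)c(Br)c(F)c3o2)cc1F`: 160 nM

In a functional assay on MCF7 cells (Homo sapiens) for cytotoxicity, read by neutral red uptake, with a stated time of 3 days (a lower number here means a stronger inhibitor, a higher number a weaker inhibitor), compound 1 gives only a limit, > 10000 nM, so its standing is bounded on one side only (the limit of > 10000 nM in this assay, at which 1 of the 2 values shown sits). Compound 2 is the sole comparator; the change at the same carbon gave an at least 62-fold lower number from compound 1 to compound 2 (1.79 log units; beyond the scatter). Compound 3, `CN(C)Cc1c(F)c(N)c2c(=O)cc(-c3ccc(N)c(F)c3)oc2c1F`, differs from compound 1 by dimethylamino in place of pentyl on a saturated chain carbon bound to an aromatic carbon. For the measured compounds named here, only that one step bears on it, and it concerns a different entering group, so its size is a loose guide. A lower number than for compound 1 is expected, the step for compound 3 estimated as an at least 5.0-fold lower number from compound 1 to compound 3 (0.69 log units; beyond the scatter). Compound 3 is expected to give about 2000 nM, within 300 nM to 10000 nM.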

Compound 3, half-maximal inhibitory concentration: 72 nM
The estimate for compound 3 lay 28-fold (1.44 log units) above the measured number; measured number outside the range, below it.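

In this assay, the hexyl chain can be replaced at this position by more than a halogen: dimethylamino in place of pentyl on a saturated chain carbon bound to an aromatic carbon gives an at least 130-fold lower number from compound 1 to compound 3 (2.14 log units; beyond the scatter). The (dimethylamino)methyl group also goes modestly past bromo, with a 2.2-fold lower number from compound 2 to compound 3 (0.35 log units; beyond the scatter). The first of these steps is open-ended, as compound 1 gives only a limit: the limit of > 10000 nM in this assay, at which 1 of the 3 values shown sits.

The compounds shown leave open whether the nitrogen or the shorter chain carries the change. A short alkyl chain, a primary amine or a morpholine at this carbon could separate the two.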